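Methylsulfanyl Enters Where a Fluoro Stood

A few compounds are considered here, and "the series" means these few. Any claim that something is new, unique, unknown or untested is made for them only; others in the source may bear on it.

Three compounds sharing one core were examined in a functional assay for agonist activity at P2Y purinoceptor 4 (Homo sapiens), read by FLIPR; on this read-out lower numbers stand for an effect already at smaller amounts and higher numbers for an effect only at larger amounts of compound. Compound 1 `O=c1c2cc(F)ccc2ccn1[C@@H]1O[C@H](COP(=O)(O)OP(=O)(O)OP(=O)(O)O)[C@@H](O)[C@H]1O` gives 3580 nM. Compound 2 `O=c1c2cc(Cl)ccc2ccn1[C@@H]1O[C@H](COP(=O)(O)OP(=O)(O)OP(=O)(O)O)[C@@H](O)[C@H]1O` carries chloro in place of fluoro on an aromatic carbon and gives 20000 nM, a change of a 5.6-fold higher number from compound 1 to compound 2 (0.75 log units; beyond the scatter). Compound 3 `O=c1c2cc(F)c(F)cc2ccn1[C@@H]1O[C@H](COP(=O)(O)OP(=O)(O)OP(=O)(O)O)[C@@H](O)[C@H]1O` carries fluoro in place of hydrogen on an aromatic carbon, and that change amounts to an at least 5.5-fold higher number from compound 1 to compound 3 (0.74 log units; beyond the scatter). In this assay compound 3 gives > 20000 nM, which is a limit of the assay and not a number. Compound 3 thus stands at the limit of > 20000 nM in this assay, at which 1 of the 3 values shown sits.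

Compound 4 `CSc1cc2ccn([C@@H]3O[C@H](COP(=O)(O)OP(=O)(O)OP(=O)(O)O)[C@@H](O)[C@H]3O)c(=O)c2cc1F` differs from compound 3 by methylsulfanyl in place of fluoro on an aromatic carbon. Within the data shown here, no measured step is the same change, yet both bear on it: each enlarged or added a substituent on an aromatic carbon of the shared core, and each raised the number, the second one up to the limit. The methylsulfanyl group that enters in place of fluoro, ortho to the remaining fluoro group, is a further enlargement at such a carbon. With compound 3 already at the limit, the step that the limit leaves unreadable from compound 3 to compound 4 is expected to be none beyond the scatter or further upward, most likely leaving the number at the limit. Compound 4 is therefore estimated at about 35000 nM, in a range from 8000 nM to 150000 nM.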

Compound 4, half-maximal effective concentration: > 20000 nM
Compound 4: only a limit was reported; the forecaster's own chance of this, stated with the estimate: 70%; the middle value lies beyond the limit too.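

Compound 4 gives > 20000 nM in this assay, which is a limit of the assay and not a number, so the step between compound 3 and compound 4 cannot be read. What can be read is the comparison with compound 1, where methylsulfanyl stands in place of hydrogen on this aromatic carbon: this assay shows an at least 5.5-fold higher number from compound 1 to compound 4 (0.74 log units; beyond the scatter). This carbon has now carried two different groups on top of the fluoro group of compound 1, fluoro in compound 3 and methylsulfanyl in compound 4, and with neither does the read-out come back within the range of the assay: the limit of > 20000 nM in this assay, at which 2 of the 4 values shown sit.

Going by these compounds, how far compound 3 and compound 4 lie beyond that limit stays open, so no order between fluoro and methylsulfanyl at this carbon can be given. Also open, on these data alone, is whether an amine or a carboxylic acid on the same carbon would keep the number near that of compound 1, which gives 3580 nM. As far as these compounds go, whether such a group would instead push the number to the limit stays open as well.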